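Thiocarboxamide on the ring nitrogen: a matched pair

A few compounds are considered here, and "the series" means these few. Any claim that something is new, unique, unknown or untested is made for them only; others in the source may bear on it.

Compound 1 `CNC(=O)c1cc(Oc2ccc(C3=NNC(c4ccc(C#N)cc4)C3)cc2)ccn1` is the reference. In a functional assay on PC-3 cells (Homo sapiens) for cytotoxicity, read by MTT assay, with a stated time of 72 h (a higher number here means a weaker inhibitor, a lower number a stronger inhibitor), compound 1 gives 9910 nM. Compound 3 `CNC(=O)c1cc(Oc2ccc(C3=NN(C(N)=S)C(c4ccc(C#N)cc4)C3)cc2)ccn1` carries the change (a group of 3 heavy atoms (1 carbon, 1 nitrogen, 1 sulfur; no ring) in place of a hydrogen atom, on an amine nitrogen in a ring); in this assay compound 3 reaches only the limit > 50000 nM. The step of an at least 5.0-fold higher number from compound 1 to compound 3 (0.70 log units; beyond the scatter) is therefore at least modest and beyond the usual scatter, and its size rests on (the limit of > 50000 nM in this assay, at which 1 of the 3 values shown sits).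

Compound 2 `CNC(=O)c1cc(Oc2ccc(C3CC(c4ccc([N+](=O)[O-])cc4)=NN3)cc2)ccn1` stands on a different core; the difference between the two cores and that of compound 1 is not broken down here. In this assay the entry for compound 2 reads "not determined" (no result reported). Compound 4 `CNC(=O)c1cc(Oc2ccc(C3CC(c4ccc([N+](=O)[O-])cc4)=NN3C(N)=S)cc2)ccn1` arises from compound 2 by a group of 3 heavy atoms (1 carbon, 1 nitrogen, 1 sulfur; no ring) in place of a hydrogen atom, on an amine nitrogen in a ring. This is the same kind of change as that from compound 1 to compound 3, not the same: here the new group sits next to the ring atom that bears a large group and two ring bonds from the ring atom that bears a 4-nitrophenyl group, whereas in the first pair it sits next to the ring atom that bears a 4-cyanophenyl group and two ring bonds from the ring atom that bears a large group.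

With compound 2 unmeasured, the expectation for compound 4 rests on the step of an at least 5.0-fold higher number from compound 1 to compound 3 (0.70 log units; beyond the scatter) and on (the limit of > 50000 nM in this assay, at which 1 of the 3 values shown sits), so a weak result is expected. Compound 4 is estimated in this assay at 70000 nM, from 20000 nM to 250000 nM, most likely reported only as a limit.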

Compound 4, half-maximal inhibitory concentration: > 50000 nM
Compound 4 gave a limit, no number; the forecaster's own chance of this, stated with the estimate: 75%; the middle value is on the limit's open side.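

In this assay compound 4 gives > 50000 nM, which is a limit and not a number. Among these compounds, with no number for compound 2, no step from compound 2 to compound 4 can be read. The compounds shown leave open how far the new group on the ring nitrogen shifts the result on the core of compound 2, and what actual values lie behind this limit: the limit of > 50000 nM in this assay, at which 2 of the 4 values shown sit.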